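Ring substitution in a series of ecdysone receptor agonists

This account rests on a few compounds, and the source may have more. Where it says the series, first, only, none or still open, it means among the compounds named here.

compound 1, `CC(C)(C)N(NC(=O)c1ccccc1)C(=O)c1ccccc1Cl`: 75.9 nM
compound 2, `CC(C)(C)N(NC(=O)c1ccccc1F)C(=O)c1ccccc1Cl`: 51.3 nM
compound 3, `Cc1ccccc1C(=O)NN(C(=O)c1ccccc1Cl)C(C)(C)C`: 72.4 nM

In an assay on cells for agonist activity at ecdysone receptor (Bombyx mori), read by a luciferase reporter, with a stated time of 24 h (on this read-out higher numbers stand for an effect only at larger amounts of compound and lower numbers for an effect already at smaller amounts), compound 3 gives the second highest of the three numbers. Its nearest neighbour is compound 1, with a step of a 1.0-fold lower number from compound 1 to compound 3 (0.02 log units; within the scatter); the step to compound 2, a 1.4-fold higher number from compound 2 to compound 3 (0.15 log units; within the scatter), is the furthest, and both lie within the scatter. The next compound in the set is compound 4, `CC(C)(C)N(NC(=O)c1cccc(F)c1)C(=O)c1ccccc1Cl`, which carries 3-fluorophenyl in place of 2-methylphenyl on a carbonyl carbon.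

Going by the values given here, two measured steps bear on this change. The step of a 1.5-fold lower number from compound 1 to compound 2 (0.17 log units; within the scatter), fluoro in place of hydrogen, and the step of a 1.4-fold higher number from compound 2 to compound 3 (0.15 log units; within the scatter), methyl in place of fluoro, are both within the scatter, so neither the methyl nor a fluorine substituent has so far moved this assay noticeably. The fluorine of compound 4 sits in a different place on the ring than that of compound 2, so the measured steps do not cover it exactly, but nothing in the set points to a step beyond the scatter. The expected step is a 1.1-fold lower number from compound 3 to compound 4 (0.05 log units; within the scatter). Compound 4 is therefore estimated to give 65 nM, between 30 nM and 140 nM.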

Compound 4, half-maximal effective concentration: 69.2 nM
Beside the measured number, compound 4's estimate is 1.1-fold (0.03 log units) below it; the measured number falls inside the stated range.
By their numbers in this assay, from the lowest: compounds 2, 4, 3 and 1 (each within the scatter of the next).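

Moving the fluorine on the ring gives a 1.3-fold higher number from compound 2 to compound 4 (0.13 log units; within the scatter) and so shows no effect of the fluorine's place on this ring in this assay. The 3-fluorophenyl group also stays level with the unsubstituted phenyl, at a 1.1-fold lower number from compound 1 to compound 4 (0.04 log units; within the scatter) and with the 2-methylphenyl group, at a 1.0-fold lower number from compound 3 to compound 4 (0.02 log units; within the scatter) in the same assay. Going by these compounds alone, all four groups on this carbonyl carbon, phenyl, 2-fluorophenyl, 2-methylphenyl and 3-fluorophenyl, therefore lie within the scatter of one another, and no compound in the set goes against this.

No measurement in hand bears on why these numbers stay level. From the compounds shown here alone, whether an amine, a carboxylic acid or a longer chain on this ring would give a step beyond the scatter stays open.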